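Hexyl carbamate in place of tert-butyl carbamate

This account rests on a few compounds, and the source may have more. Where it says the series, first, only, none or still open, it means among the compounds named here.

Three compounds share one core and differ only in the chain carried on the aromatic oxygen. Compound 1 `COc1cc2ncnc(-n3nc(-c4ccccn4)nc3N)c2cc1OCCCN1CC(C)OC(C)C1` gives 1600 nM in an assay on MCF7 cells for inhibition of Serine-protein kinase ATM (Homo sapiens), read by immunofluorescence, with a stated time of 1 h; a lower number here means a stronger inhibitor, a higher number a weaker inhibitor. Compound 2 `CCN(CC)C(=O)COc1cc2c(-n3nc(-c4ccccn4)nc3N)ncnc2cc1OC` gives 5300 nM in this assay. Compound 3 `COc1cc2ncnc(-n3nc(-c4ccccn4)nc3N)c2cc1OCCCNC(=O)OC(C)(C)C` gives 900 nM in this assay, the lowest of the three numbers; the step of a 1.8-fold lower number from compound 1 to compound 3 (0.25 log units; within the scatter) lies within the scatter, while the step of a 5.9-fold lower number from compound 2 to compound 3 (0.77 log units; beyond the scatter) lies beyond it, as does a 3.3-fold higher number from compound 1 to compound 2 (0.52 log units; beyond the scatter).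

Compound 4 `CCCCCCOC(=O)NCCCOc1cc2c(-n3nc(-c4ccccn4)nc3N)ncnc2cc1OC` differs from compound 3 by hexyl in place of tert-butyl on an oxygen next to a carbonyl group. Among the compounds with values here, no measured step touches this oxygen: the three measured steps all exchange the whole chain end, and the carbamate of compound 3 is kept in compound 4. The data therefore give no direct lead, and the expected step of a 1.1-fold higher number from compound 3 to compound 4 (0.05 log units; within the scatter) in this assay is estimated as none beyond the scatter. Compound 4 is expected to give about 1000 nM in this assay, within a range from 350 nM to 3000 nM.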

Compound 4, half-maximal inhibitory concentration: 28600 nM
The estimate for compound 4 lay 29-fold (1.46 log units) below the measured number; measured number outside the range, above it.
By their numbers in this assay, from the lowest: compounds 3 and 1 (each within the scatter of the next); then compound 2; then compound 4.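

Hexyl in place of tert-butyl on an oxygen next to a carbonyl group gives a 32-fold higher number from compound 3 to compound 4 (1.50 log units; beyond the scatter) in this assay, the largest step among these compounds, so the group on this oxygen matters even with the carbamate and the chain kept. The earlier steps shown here exchanged the whole chain end and could not show this: the carbamate alone does not set the number, for the hexyl carbamate end gives a 5.4-fold higher number from compound 2 to compound 4 (0.73 log units; beyond the scatter) and also an 18-fold higher number from compound 1 to compound 4 (1.25 log units; beyond the scatter) when set against the other chain ends. Nothing measured here accounts for the size of this step.

With only tert-butyl and hexyl on this oxygen, chain length and branching cannot be told apart. An ethyl, isopropyl or n-butyl group, or a ring such as cyclohexyl or benzyl, would separate the two.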